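The compounds below may be only part of what the source reports. "The series", "measured", "known", "first", "only" and "open" are said of these compounds alone.

The series shares one core, seen in compound 1 `O=C(CCSc1nnc(-c2ccncc2)s1)Nc1ccc(Cl)cc1`, whose cytotoxicity is read in an ADME assay on BHK-21 cells (Mesocricetus auratus) for cytotoxicity, with a stated time of 3 days; on this read-out higher numbers stand for lower toxicity in this test and lower numbers for higher toxicity in this test. In this assay compound 1 gives 8210 nM. Compound 3 `O=C(CCSc1nnc(-c2ccncc2)s1)Nc1c(Cl)cccc1Cl` is the closely related member with the other anilide. In this assay compound 3 gives 10300 nM. Among the measured compounds shown here, the one step that has been measured between them, a 1.3-fold higher number from compound 1 to compound 3 (0.10 log units; within the scatter), stays inside the usual scatter. Compound 2 `CC(Sc1nnc(-c2ccncc2)s1)C(=O)Nc1ccccc1` carries the branched linker and the plain anilide. For compound 2 this assay reports only a limit, > 50000 nM, and compound 2 therefore stands at the top of the numbers shown, with no exact value, as noted by the limit of > 50000 nM in this assay, at which 1 of the 3 values shown sits.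

The step under study leads to compound 4 `CC(Sc1nnc(-c2ccncc2)s1)C(=O)Nc1ccc(Cl)cc1`, which differs from compound 2 by chloro in place of hydrogen on an aromatic carbon. For the measured compounds named here, no measured step reports this exact change on this core, and the only measured step, a 1.3-fold higher number from compound 1 to compound 3 (0.10 log units; within the scatter), concerns two chlorinated anilides rather than the entry of the first chloro group. Compound 1, which carries the same 4-chlorophenyl group, sits well inside the measurable range. For compound 4 the account therefore expects a move out of the limit region, a step of an at least 2.0-fold lower number from compound 2 to compound 4 (0.30 log units; that floor lies within the scatter), toward somewhat higher toxicity, with the estimate for compound 4 placed at 25000 nM between 8000 nM and 60000 nM, pending the measurement.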

Compound 4, half-maximal cytotoxic concentration: > 50000 nM
Compound 4: no number, only a limit; the forecaster's own chance of this, stated with the estimate: 35%; at least 2.0-fold (0.30 log units) between middle value and limit.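

In this assay, compound 4 returns only a limit, as compound 2 does, so no step can be read between compound 2 and compound 4: the limit of > 50000 nM in this assay, at which 2 of the 4 values shown sit.

The compounds shown leave open where the true values of compound 2 and compound 4 lie, and whether chloro in place of hydrogen on this aromatic carbon changes the read-out at all.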